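A few compounds are considered here, and "the series" means these few. Any claim that something is new, unique, unknown or untested is made for them only; others in the source may bear on it.

Measured compounds in an ADME assay on HEL cells (Homo sapiens) for cytotoxicity, with a stated time of 3 days; on this read-out higher numbers stand for lower toxicity in this test and lower numbers for higher toxicity in this test:
- compound 1 `C=Cc1ccc(-c2cc(C)c3ncc(CSCCc4ccccc4)n3c2)cc1`: 20 ug/mL
- compound 2 `Cc1cc(-c2ccsc2)cn2c(CSCc3ccccc3)cnc12`: 4 ug/mL
- compound 3 `Cc1cc(-c2ccco2)cn2c(CSCCc3ccccc3)cnc12`: a limit of the assay, > 4 ug/mL

Compound 2 stands at the lowest of the two numbers shown. Its nearest neighbour is compound 1, whose number is higher by a gap beyond the scatter. Compound 3 gives only a limit of the assay; for this reason the step that the limit leaves unreadable from compound 1 to compound 3 cannot be read, as stated by the limit of > 4 ug/mL in this assay, at which 1 of the 3 values shown sits.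

Compound 4 `Cc1cc(-n2cccc2)cn2c(CSCc3ccccc3)cnc12` is not yet measured. It differs from compound 2 by 1H-pyrrol-1-yl in place of thiophen-3-yl on an aromatic carbon. No measured step runs between two read numbers at this position, so nothing shown bears directly on the change; the only comparable swap of a five-membered aromatic ring at this carbon is the unreadable one from compound 1 to compound 3. With no readable precedent, no step beyond the scatter is expected in this assay, and the step of no change at the digits printed from compound 2 to compound 4 (within the scatter) is estimated as essentially flat. Compound 4 is therefore expected at 4 ug/mL, within 2 ug/mL to 8 ug/mL.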

Compound 4, minimum cytotoxic concentration: 20 ug/mL
The estimate for compound 4 lay 5.0-fold (0.70 log units) below the measured number; measured number outside the range, above it.
By their numbers in this assay, from the lowest: compound 2; then compounds 1 and 4 (each within the scatter of the next).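

In this assay, among these compounds, this aromatic carbon is not indifferent to the choice of five-membered ring: 1H-pyrrol-1-yl in place of thiophen-3-yl gives a 5.0-fold higher number from compound 2 to compound 4 (0.70 log units; beyond the scatter), the first readable step at this position, towards lower toxicity in this test. The two groups match in what is counted, with 5 heavy atoms and one five-membered aromatic ring with 1 hetero atom each, so equal size and ring count do not make them interchangeable here. Nothing measured among these compounds accounts for the step.

Compound 3 gives only a limit of the assay, > 4 ug/mL, and the step to it cannot be read. Open, going by these compounds, are whether the step holds with the side chain of compound 1, and how an amine or a carboxylic acid at this aromatic carbon would read.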